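A few compounds are considered here, and "the series" means these few. Any claim that something is new, unique, unknown or untested is made for them only; others in the source may bear on it.

Measured so far in an in vivo ADME assay on the whole organism for pharmacokinetics, with Mus musculus as the target; a lower number here means that a smaller share of the oral dose reaches the circulation, a higher number that a larger share of the oral dose reaches the circulation:

compound 1 `NC(=O)[C@@H](CCC(F)(F)F)N(CC1COC1)S(=O)(=O)c1ccc(Cl)cc1`: < 5%
compound 2 `CC1(C)C[C@@H](CN([C@H](CCC(F)(F)F)C(N)=O)S(=O)(=O)c2ccc(Cl)cc2)O1`: < 5%

Compound 1 gives < 5% in this assay, which is a limit of the assay and not a number. Compound 2 likewise reports only a limit, < 5%. Compound 2 therefore stands at the limit of < 5% in this assay, at which 2 of the 2 values shown sit, with no numerical position within the series. The step that the two limits leave unreadable from compound 1 to compound 2 connects the two and stays unreadable.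

Compound 3 `NC(=O)[C@@H](CCC(F)(F)F)N(C[C@@H]1CCO1)S(=O)(=O)c1ccc(Cl)cc1` is not yet measured. It differs from compound 2 by oxetan-2-yl in place of 4,4-dimethyloxetan-2-yl on a saturated chain carbon bound to a sulfonamide nitrogen. Among the measured compounds shown here, the only measured step at this position is a step that the two limits leave unreadable from compound 1 to compound 2; it is unreadable in size, and all it shows is that both oxetane variants remain at the limit. For the measured compounds named here, no measured step gives a readable direction for the change to compound 3.

Compound 3 is therefore expected to remain at the limit as well, with an estimate of 3% and a range from 1% to 10%. The expected step that the limit leaves unreadable from compound 2 to compound 3 is none beyond the scatter.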

Compound 3, oral bioavailability: < 5%
Compound 3 gave a limit, no number; the forecaster's own chance of this, stated with the estimate: 70%; the middle value is on the limit's open side.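

No step among compound 1, compound 2 and compound 3 can be read in this assay, since each gives a limit and not a number: the limit of < 5% in this assay, at which 3 of the 3 values shown sit.

The compounds shown leave open how far these oxetane variants differ in oral bioavailability, and which change on this saturated chain carbon, if any, gives a readable value.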